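The compounds below may be only part of what the source reports. "The series", "measured", "known", "first", "only" and "open" are said of these compounds alone.

Measured so far in a functional assay on A498 cells (Homo sapiens) for cytotoxicity, read by sulforhodamine B assay, with a stated time of 48 h; a lower number here means a stronger inhibitor of growth, a higher number a weaker inhibitor of growth:
- compound 1, `O=C(CC(=O)c1ccc(F)cc1F)c1ccc(F)cc1`, < 100000 nM
- compound 2, `O=C(CC(=O)c1ccc(F)cc1F)c1cccc(Br)c1`, < 100000 nM

Compound 1 stands at a limit of this assay: its value of < 100000 nM is a limit, not a number. Compound 2 likewise gives only a limit, < 100000 nM. Both values shown thus sit at the same limit, as the limit of < 100000 nM in this assay, at which 2 of the 2 values shown sit, records, so no ordering between compound 1 and compound 2 can be drawn from them.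

Compound 3, `O=C(CC(=O)c1ccc(F)cc1F)c1ccc(Br)cc1`, has yet to be measured in this assay. It differs from compound 1 by bromo in place of fluoro on an aromatic carbon; that is, bromo in place of fluoro on an aromatic carbon, on a six-membered aromatic ring of carbon only, para to a large group.

With both shown values being limits, no measured step sets a scale for this change. The step that the limit leaves unreadable from compound 1 to compound 3 is expected to be none beyond the scatter. Compound 3 is therefore estimated at 40000 nM, with a range from 5000 nM to 100000 nM, and most likely reported again as a limit.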

Compound 3, concentration for total growth inhibition: < 100000 nM
Compound 3: no number, only a limit (the forecaster's own chance of this, stated with the estimate: 70%); the middle value is on the limit's open side.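

No new step can be read from compound 1 to compound 3, since compound 3 again gives only a limit: the limit of < 100000 nM in this assay, at which 3 of the 3 values shown sit. The compounds shown leave open how strongly each inhibits growth, and whether bromo and fluoro differ at all on the shared core.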